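Chain length and serum half-life in nitrooxy salicylate esters

This account rests on a few compounds, and the source may have more. Where it says the series, first, only, none or still open, it means among the compounds named here.

Measured so far:
compound 1 `O=C(CCCO[N+](=O)[O-])Oc1ccccc1C(=O)O` — 0.47 h
compound 2 `O=C(CCO[N+](=O)[O-])Oc1ccccc1C(=O)O` — 0.26 h
compound 3 `O=C(CC(CO[N+](=O)[O-])O[N+](=O)[O-])Oc1ccccc1C(=O)O` — 0.28 h

In an ADME assay on a cell-free system (serum, Homo sapiens) for metabolic stability (on this read-out higher numbers stand for a longer-lived compound and lower numbers for a shorter-lived compound), compound 1 holds the highest of the three numbers, but none of its steps reaches beyond the scatter: a 1.8-fold lower number from compound 1 to compound 2 (0.26 log units; within the scatter) and a 1.7-fold lower number from compound 1 to compound 3 (0.22 log units; within the scatter). The pair compound 2 and compound 3 is likewise flat, a 1.1-fold higher number from compound 2 to compound 3 (0.03 log units; within the scatter). Across the series, shortening or branching the nitrooxy-bearing chain has left this assay essentially unchanged.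

Compound 4 `O=C(CCCCCCO[N+](=O)[O-])Oc1ccccc1C(=O)O` is the next member. The change from compound 1 is 3-(nitrooxy)propyl in place of nitrooxy on a saturated chain carbon, three bonds along the chain from a carbonyl carbon. The step that bears on it most directly is a 1.8-fold lower number from compound 1 to compound 2 (0.26 log units; within the scatter), where one chain carbon was removed rather than added and the number stayed within the scatter; a 1.7-fold lower number from compound 1 to compound 3 (0.22 log units; within the scatter) also shows that altering the chain did not move the read-out. For the measured compounds named here, no measured step rises beyond the scatter, so no step beyond it is expected here either, with at most a slight lean toward the longer-lived side given that compound 1 already sits at the top of the series.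

Compound 4 is expected to give 0.6 h, in a range from 0.3 h to 1.2 h. The expected step of a 1.3-fold higher number from compound 1 to compound 4 (0.11 log units; within the scatter) stays inside the scatter.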

Compound 4, half-life: 1.19 h
For compound 4 the middle estimate is 2.0-fold (0.30 log units) below the measured one, within the range that was stated.
By their numbers in this assay, from the lowest: compounds 2, 3 and 1 (each within the scatter of the next); then compound 4.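

In this assay, 3-(nitrooxy)propyl in place of nitrooxy on a saturated chain carbon, three bonds along the chain from a carbonyl carbon, gives a 2.5-fold higher number from compound 1 to compound 4 (0.40 log units; beyond the scatter) and is the only step among the compounds shown that lies beyond the scatter. This position can therefore move the half-life, a response that the flat steps among compounds 1, 2 and 3 did not reveal, although the size of the step is modest and it rests on this single pair. No measured evidence accounts for the rise, so the result stands as an observation on chain extension alone.

The compounds shown leave open whether a longer chain at this place would continue the rise or whether the effect levels off, since a single extended member cannot define a trend in chain length. They also leave open whether the rise depends on the nitrooxy group itself, which an amine or a hydroxyl group in its place on the same 3-carbon extension would help to separate from the contribution of the added chain.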